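Replacing a two-ring group with phenoxy in compound 3

The source may hold more compounds than are shown below. What is called first, only, known or untested is meant among the compounds shown, and "the series" means these compounds.

In an ADME assay on HepG2 2.2.15 cells (Homo sapiens) for cytotoxicity (on this read-out lower numbers stand for higher toxicity in this test and higher numbers for lower toxicity in this test), two compounds sharing one core have been measured. Compound 1 (`CC(=O)NCC(=O)OCCc1c(-c2ccccc2Cl)c2cc(Cl)ccc2[nH]c1=O`) gives 110000 nM, and compound 2 (`O=C(CN1C(=O)c2ccccc2C1=O)OCCc1c(-c2ccccc2Cl)c2cc(Cl)ccc2[nH]c1=O`) gives 960000 nM, the higher of the two numbers, so compound 2 is the less toxic of the pair in this test. Going by the values given here, the only measured step is an 8.7-fold higher number from compound 1 to compound 2 (0.94 log units; beyond the scatter). It is modest but beyond the usual scatter, and it accompanies a larger group on the saturated chain carbon bound to a carbonyl carbon. Compound 3 (`O=C(COc1ccccc1)OCCc1c(-c2ccccc2Cl)c2cc(Cl)ccc2[nH]c1=O`) has not yet been measured. Its change from compound 2 is a group of 7 heavy atoms (6 carbon, 1 oxygen; one six-membered aromatic ring of carbon only) in place of a group of 11 heavy atoms (8 carbon, 1 nitrogen, 2 oxygen; one five-membered non-aromatic ring with 1 hetero atom, one six-membered aromatic ring of carbon only), on a saturated chain carbon bound to a carbonyl carbon. The phenoxy group appears in neither measured compound, so that single step offers only a loose guide. The group in compound 3 is smaller than that in compound 2 and larger than that in compound 1, so compound 3 is expected to fall between the measured compounds, nearer neither with confidence. A modest fall is expected, a 3.0-fold lower number from compound 2 to compound 3 (0.48 log units; beyond the scatter). For compound 3 the estimated value is 320000 nM, with an expected range of 100000 nM to 900000 nM.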

Compound 3, half-maximal cytotoxic concentration: 81000 nM
For compound 3 the middle estimate is 4.0-fold (0.60 log units) above the measured one, outside the stated range (below it).
By their numbers in this assay, from the lowest: compounds 3 and 1 (each within the scatter of the next); then compound 2.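

With phenoxy on the saturated chain carbon bound to a carbonyl carbon, this assay gives a 12-fold lower number from compound 2 to compound 3 (1.07 log units; beyond the scatter), a large step that is wider than the one first seen at this place. Phenoxy in place of acetamido gives a 1.4-fold lower number from compound 1 to compound 3 (0.13 log units; within the scatter), so these two groups cannot be told apart here even though phenoxy has more heavy atoms and a six-membered aromatic ring, and group size alone does not order the three compounds. Among the three, only the two-ring group of compound 2 stands apart from the others, and no measurement is available that explains this.

As far as these compounds go, it remains open whether the higher number of compound 2 needs the whole two-ring group, or whether a simpler group containing one of its parts would be enough. It is also unknown whether an amine, a carboxylic acid or a longer chain at this place would stay with compound 1 and compound 3 or move towards compound 2.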